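Chloro removed from the benzamide of compound 1

The source may report more compounds than this note shows. Statements on the series, on what has been measured and on what is new or still open speak of the compounds shown alone.

Compound 1 `CC(C)C(=O)N1CCc2cc(CNC(=O)c3ccc(Cl)cc3)ccc21` is the reference for this step. In an assay on HEK293 cells for inhibition of Indoleamine 2,3-dioxygenase 1 (Homo sapiens), tested at 10 uM (on this read-out higher numbers stand for more inhibition at the one concentration tested (going by the name of the read-out) and lower numbers for less inhibition), compound 1 gives 92%, the top of the three numbers measured. Compound 3 `CC(C)CC(=O)N1CCc2cc(CNC(=O)c3cccnc3)ccc21`, carrying a pyridine-3-carboxamide and a longer acyl group on the core, gives 86% in this assay, a number within the usual scatter of compound 1, so no order between the two is claimed. Compound 2 `CCC(=O)NCc1ccc2c(c1)CCN2C(=O)c1ccccc1`, with the amides arranged the other way round, gives 41% in this assay, far below compound 1 and beyond the scatter. Two of three compounds therefore sit high, and the lone low number belongs to a rearranged skeleton rather than to a change on the aryl amide.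

Compound 4 `CC(C)C(=O)N1CCc2cc(CNC(=O)c3ccccc3)ccc21` differs from compound 1 in one place: hydrogen in place of chloro on an aromatic carbon. The chloro leaves the 4-chlorophenyl, and a plain phenyl remains. For the measured compounds named here, no measured pair in the set shows this change, so its size is unknown here; compound 2 carries an unsubstituted phenyl but on a different amide and is not a direct comparison. A moderate drop is expected, smaller than the gap from compound 1 to compound 2. For compound 4 the expected step from compound 1 is a number 14 percentage points lower from compound 1 to compound 4 (beyond the scatter). Compound 4 is thus estimated at 78%, between 55% and 95%.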

Compound 4, a percentage reported as inhibition, at one concentration (the size of the read-out at that concentration, not a potency): 100%
Beside the measured number, compound 4's estimate is 22 percentage points below it, and the stated range ends below it.
By their numbers in this assay, from the lowest: compound 2; then compounds 3, 1 and 4 (each within the scatter of the next, the first and the last beyond it).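

In this assay, for the compounds shown here, replacing the 4-chlorophenyl with a phenyl gives a number 8 percentage points higher from compound 1 to compound 4 (within the scatter), the first step that can be read from a single change. The chloro on this aromatic carbon is therefore not needed for a high read-out at the one concentration tested: the plain phenyl of compound 4 gives 100%, and no order is claimed between compound 4 and compound 1. Nothing available bears on why removing this one chlorine atom leaves the number within the scatter.

Still open, from the compounds shown here alone, is whether a methoxy group, an amine or a carboxylic acid on the same aromatic carbon of the phenyl would also keep the read-out high, or whether a wider change at this place would bring the number down. With compound 4 at 100%, a percentage at one concentration leaves little room to separate further analogues of this kind, and potency across the series remains undefined by this read-out.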